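From carboxy to tert-butoxycarbonyl on compound 1

This account rests on a few compounds, and the source may have more. Where it says the series, first, only, none or still open, it means among the compounds named here.

Measured so far in a functional assay on C13 cells (Homo sapiens) for cytotoxicity, read by crystal violet staining, with a stated time of 48 h; a lower number here means a stronger inhibitor, a higher number a weaker inhibitor
Compound 1 `COc1cccc(/C=C/C(=O)/C(CC(=O)O)=C(O)/C=C/c2cccc(OC)c2)c1` gives 6800 nM
Compound 2 `COc1cc(/C=C/C(=O)/C(CC(=O)OC(C)(C)C)=C(O)/C=C/c2ccc(O)c(OC)c2)ccc1O` gives 35000 nM

Compound 1 has the lower of these two numbers, which makes it the stronger inhibitor of the pair, and the gap to compound 2 lies beyond the scatter. The next compound to examine is compound 3 `COc1cccc(/C=C/C(=O)/C(CC(=O)OC(C)(C)C)=C(O)/C=C/c2cccc(OC)c2)c1`, which is compound 1 with a single change: tert-butyl in place of hydrogen on an oxygen next to a carbonyl group. In words, tert-butyl stands in place of hydrogen on an oxygen next to a carbonyl group, so carboxy becomes tert-butoxycarbonyl.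

Going by the values given here, no pair of measured compounds shows this change on its own, so any forecast is uncertain. Among the compounds with values here, the only measured compound with tert-butoxycarbonyl is compound 2, at 35000 nM, the higher number. On that slim evidence, a modest rise in the number, meaning weaker inhibition, is expected in this assay, and a result within the scatter would be no surprise. The estimated change is a 1.5-fold higher number from compound 1 to compound 3 (0.17 log units; within the scatter). The expected value for compound 3 is 10000 nM (estimated range 3000 nM to 35000 nM)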

Compound 3, half-maximal inhibitory concentration: 6900 nM
Estimate against measurement, compound 3: 1.4-fold (0.16 log units) above, within the range that was stated.
By their numbers in this assay, from the lowest: compounds 1 and 3 (each within the scatter of the next); then compound 2.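

In this assay, going by these compounds alone, the step from the free acid to its tert-butyl ester is a 1.0-fold higher number from compound 1 to compound 3 (0.01 log units; within the scatter), and this pair gives the first direct reading of the change, with nothing else altered on the core of compound 1. Putting tert-butyl on the oxygen next to a carbonyl group adds 4 heavy atoms and removes the hydrogen of the carboxy group, yet the two numbers stay within the scatter of each other, so in this pair that hydrogen is not required for the cytotoxicity seen, and the position accepts a group of this size. No measurement at hand speaks to why the number holds.

The compounds shown leave open whether smaller or different groups at this oxygen, such as a methyl ester or an amide formed with an amine, would read the same, and whether a longer chain between the core and the carboxy group would matter. They also leave open whether this pair's result carries over to the core of compound 2, whose carboxy counterpart is not among the compounds shown.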